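This account rests on a few compounds, and the source may have more. Where it says the series, first, only, none or still open, it means among the compounds named here.

Measured in an ADME assay on HaCaT cells (Homo sapiens) for cytotoxicity, read by MTT assay, with a stated time of 72 h; a lower number here means a stronger inhibitor, a higher number a weaker inhibitor:
- compound 1 `COc1ccc(Nc2nnnn2-c2ccccc2Cl)cc1` gives 100000 nM
- compound 2 `COc1ccc(-n2nnnc2Nc2ccc(Br)cc2)cc1` gives 131000 nM
- compound 3 `COc1ccc(-n2nnnc2Nc2cccc(Cl)c2)cc1` gives 141000 nM

Compound 1 has the lowest number of the three, but its value lies within the usual scatter of those of compound 2 and compound 3, so the numbers give no real order. Not yet measured is compound 4 `COc1ccc(Nc2nnnn2-c2cccc(Cl)c2)cc1`, an isomer of compound 1 with 3-chlorophenyl in place of 2-chlorophenyl on an aromatic nitrogen. Among the measured compounds shown here, only one measured step bears on this change, and only indirectly. It is a 1.1-fold higher number from compound 2 to compound 3 (0.03 log units; within the scatter), which lies within the scatter. For the measured compounds named here, that step also brings in 3-chlorophenyl, though not on the aromatic nitrogen changed here, and no measured pair moves the chlorine around the ring. On these data alone, no step beyond the scatter is therefore expected in this assay, and the direction stays open. The expected change is a 1.2-fold higher number from compound 1 to compound 4 (0.06 log units; within the scatter). For compound 4 the estimated value is 115000 nM, with an expected range of 65000 nM to 200000 nM.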

Compound 4, half-maximal inhibitory concentration: 103000 nM
Compound 4: middle estimate off by 1.1-fold (0.05 log units), on the high side; the measured number falls inside the stated range.
By their numbers in this assay, from the lowest: compounds 1, 4, 2 and 3 (each within the scatter of the next).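

In this assay the change to 3-chlorophenyl in place of 2-chlorophenyl on an aromatic nitrogen gives a 1.0-fold higher number from compound 1 to compound 4 (0.01 log units; within the scatter). This pair isolates the chlorine's place on the phenyl ring, which the earlier step did not, and with the rest of the core held constant the two placements cannot be told apart in this read-out. No measurement bearing on why the pair reads this way is available.

The compounds shown carry only chlorine or bromine on the phenyl ring, so it remains open whether a carboxylic acid or an amine in place of the chlorine would give a step beyond the scatter. Also open, on these data alone, is whether 3-chlorophenyl and 2-chlorophenyl would remain indistinguishable in a series with a different group in place of the methoxy.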